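The compounds below may be only part of what the source reports. "The series", "measured", "known", "first", "only" and "open" are said of these compounds alone.

Compound 1 `CCCCCCCCCCCCCCCCc1nc(N2CCC2)c(C)c(C)c1O`: in a functional assay on cells (Lymphocyte, Homo sapiens) for inhibition, read by flow cytometry, using a membrane potential dye, with a stated time of 16 h, tested at 100 nM (on this read-out lower numbers stand for a weaker effect and higher numbers for a stronger effect at the one concentration tested), compound 1 gives 54%.
Compound 2 `Cc1c(N(C)C)nc(CCCCCCCCCCO)c(O)c1C`: in this assay compound 2 gives 24%.
Compound 3 `CCCCCCCCCCCCCCCCCCCc1nc(N(C)C)c(C)c(C)c1O`: in this assay compound 3 gives 24%.

Compound 3 stands level with compound 2 at the digits shown, and the two together give the lowest numbers of the three. Compound 2 is its nearest neighbour, with no change between them within the scatter; compound 1 is the furthest, its number lying higher by a margin beyond the scatter.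

The next compound is compound 4 `CCCCCCCCCCCCCCCCc1nc(N(C)C)c(C)c(C)c1O`. It differs from compound 3 by hydrogen in place of propyl on a saturated chain carbon, ten or more bonds along the chain from an aromatic carbon.

Among the measured compounds shown here, only one measured step bears on a change out along the chain: no change at the digits printed from compound 2 to compound 3 (within the scatter). That step, at the same kind of place on the chain, moved the number by nothing beyond the scatter. A shortening of the same chain by propyl is therefore expected to behave alike, and the step of a number 6 percentage points higher from compound 3 to compound 4 (within the scatter) is expected to stay within the scatter. For the measured compounds named here, compound 1 shares the chain length of compound 4 but not its amine, and no step between them is available; its higher number is noted but not relied upon.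

Compound 4 is therefore estimated at 30%, within a range from 14% to 50%.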

Compound 4, a percentage reported as activity, at one concentration (the size of the read-out at that concentration, not a potency): 67%
Beside the measured number, compound 4's estimate is 37 percentage points below it; measured number above the stated range.
By their numbers in this assay, from the lowest: compounds 2 and 3 (each within the scatter of the next); then compound 1; then compound 4.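

In this assay, hydrogen in place of propyl on a saturated chain carbon, ten or more bonds along the chain from an aromatic carbon, gives a large step (a number 43 percentage points higher from compound 3 to compound 4 (beyond the scatter)), so changes this far out along the chain are not silent. Hexyl in place of hydroxy at the same place also gives a large step (a number 43 percentage points higher from compound 2 to compound 4 (beyond the scatter)), whereas nonyl in place of hydroxy gives none (no change at the digits printed from compound 2 to compound 3 (within the scatter)), so among these three compounds the outcome depends on which group enters and does not simply follow the addition of carbons to the chain. The amine counts as well, though less, since dimethylamino in place of azetidin-1-yl on an aromatic carbon gives a modest step (a number 13 percentage points higher from compound 1 to compound 4 (beyond the scatter)).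

No measurement is available to explain any of these differences. Still open, on these data alone, are how the number runs with a chain only slightly longer or shorter than that of compound 4, whether a hydroxy or a carboxylic acid at the end of that chain would be tolerated, and whether a pyrrolidine or a piperidine in place of dimethylamino would hold the effect seen at this single tested concentration.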